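The source may report more compounds than this note shows. Statements on the series, on what has been measured and on what is new or still open speak of the compounds shown alone.

Among the measured compounds shown here, compound 1 `CCCOC1=C(CCC)C(=O)/C(=C(O)/C=C/c2ccccc2)C(=O)C1(CCC)CCC` holds the lower of the two numbers measured so far: in a functional assay on MCF7 cells (Homo sapiens) for antiproliferative activity, read by sulforhodamine B assay, with a stated time of 3 days (a lower number here means that less compound is needed, a higher number that more compound is needed for the effect), compound 1 gives 1.6 uM. For the measured compounds named here, compound 2 `COC1=C(CCC(C)C)C(=O)/C(=C(O)/C=C/c2ccccc2)C(=O)C1(CCC(C)C)CCC(C)C` differs from compound 1 in several places at once, and in this assay compound 2 gives 25.2 uM, a higher number that sits beyond the scatter; with more than one change between them, the pair shows only that the two values differ. Compound 3 `CCCCOC1=C(CCC)C(=O)/C(=C(O)/C=C/c2ccccc2)C(=O)C1(CCC)CCC` follows compound 1 by a single change: methyl in place of hydrogen on a saturated chain carbon, three bonds along the chain from an oxygen on an unsaturated carbon. Going by the values given here, no measured pair isolates the length of this ether chain on the shared core, so there is no step to lean on. The expected step of a 1.2-fold higher number from compound 1 to compound 3 (0.07 log units; within the scatter) lies within the usual scatter, leaning slightly toward a higher number. Compound 3 is therefore expected to come in at 1.9 uM, with a range from 0.7 uM to 5 uM.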

Compound 3, concentration for half-maximal effect: 5.3 uM
Beside the measured number, compound 3's estimate is 2.8-fold (0.45 log units) below it; the measured number lies above the stated range.
By their numbers in this assay, from the lowest: compound 1; then compound 3; then compound 2.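

In this assay the ether chain on the shared core gets its first single-change reading: propyl to butyl, with methyl in place of hydrogen three bonds along the chain from an oxygen on an unsaturated carbon, gives a 3.3-fold higher number from compound 1 to compound 3 (0.52 log units; beyond the scatter) and so a step that can be read on its own. This position is therefore not indifferent to chain length: one added carbon is enough to move the number, and it moves toward more compound being needed. Nothing measured here speaks to why the number moves.

Going by these compounds, whether a shorter ethyl chain would bring a lower number, or a longer pentyl chain would continue the rise, stays open. On these data alone, how an amine or a carboxylic acid carried on this chain would read is equally open, and compound 2 cannot settle it, since it differs from compound 1 in several places.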